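The source may report more compounds than this note shows. Statements on the series, on what has been measured and on what is new or still open speak of the compounds shown alone.

Measured compounds:
Compound 1 `COc1cccc(Nc2nc(Oc3cccc(NC(=O)/C=C/C(C)C)c3)c3sccc3n2)c1` gives 23400 nM in a functional assay on A-431 cells (Homo sapiens) for inhibition, read by MTT assay, with a stated time of 72 h; a higher number here means a weaker inhibitor, a lower number a stronger inhibitor.
Compound 2 `COc1ccc(Nc2nc(Oc3cccc(NC(=O)C=C(C)C)c3)c3sccc3n2)cn1` gives > 50000 nM in this assay.

Compound 1 is the only one of the two that yields a number in this assay. For compound 2 the result in this assay is a limit, not a number; it sits at the limit of > 50000 nM in this assay, at which 1 of the 2 values shown sits. So compound 2 stands at the weak end of what the method can report, and its true value is unknown beyond that.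

Compound 3 `COc1ccc(Nc2nc(Oc3cccc(NC(=O)/C=C/C(C)C)c3)c3sccc3n2)cn1` is not yet measured. It differs from compound 2 in one place: 3-methylbut-1-en-1-yl in place of 2-methylprop-1-en-1-yl on a carbonyl carbon. Compound 1 carries the same 3-methylbut-1-en-1-yl chain on the carbonyl carbon, and its value shows that a molecule built around this core with that chain can reach a measurable, though weak, result.

Going by the values given here, since no measured step between two compounds is available, the size of the change from compound 2 to compound 3 cannot be read from the data. The expected step from compound 2 to compound 3 is a number no higher from compound 2 to compound 3 (the limit leaves the size open), that is, nothing clearly beyond the scatter in either direction. Compound 3 is therefore expected to give about 50000 nM, with a range from 20000 nM to 150000 nM, and a limit rather than a number is a real possibility.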

Compound 3, half-maximal inhibitory concentration: > 50000 nM
Compound 3 gave a limit, no number; the forecaster's own chance of this, stated with the estimate: 60%; the middle value sits exactly at the limit.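

In this assay compound 3 gives > 50000 nM, which is a limit and not a number. With the 3-methylbut-1-en-1-yl chain the same in both compounds, 6-methoxypyridin-3-yl in place of 3-methoxyphenyl on a nitrogen on an aromatic ring gives an at least 2.1-fold higher number from compound 1 to compound 3 (0.32 log units; beyond the scatter), so the change on this nitrogen, and not only the chain on the carbonyl carbon, bears on the result, and the measurable value of compound 1 does not carry over to its 6-methoxypyridin-3-yl counterpart. The step between the two chains on the carbonyl carbon cannot be read, and with 6-methoxypyridin-3-yl on the nitrogen neither chain gives a number: the limit of > 50000 nM in this assay, at which 2 of the 3 values shown sit.

From the compounds shown here alone, how far compound 2 and compound 3 lie past the limit stays open, and with it whether the two chains differ at all in this assay. Also open, going by these compounds, is whether a dimethylamino group at the end of the chain on the carbonyl carbon, or a plain phenyl on the nitrogen in place of 6-methoxypyridin-3-yl, would give a number in this assay.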